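Trimming a Chloro Group on a Long-Chain Anilide

The compounds below may be only part of what the source reports. "The series", "measured", "known", "first", "only" and "open" are said of these compounds alone.

Compound 1 `Cn1c(Cc2nn(C)c(=O)c3ccccc23)nnc1SCCCCCCCC(=O)Nc1ccc(F)cc1F` gives 2300 nM in an assay on isolated protein (Mus musculus) for inhibition of IL15-IL15 receptor (Homo sapiens), read by resazurin assay, with stated times of 30 min and 2.5 days; a lower number here means a stronger inhibitor, a higher number a weaker inhibitor.
Compound 2 `Cn1c(Cc2nn(C)c(=O)c3ccccc23)nnc1SCCCC(=O)Nc1ccc(Cl)cc1Cl` gives 9800 nM.
Compound 3 `Cn1c(Cc2nn(C)c(=O)c3ccccc23)nnc1SCCCCCCCCCCC(=O)Nc1ccc(Cl)cc1Cl` gives 3300 nM.

Among these three numbers, compound 3 stands second highest. Its nearest neighbour is compound 1, and that gap lies within the usual scatter, so neither can be called the stronger of the two. Compound 2 sits furthest away, with a higher number that lies beyond the scatter. Compound 4 `Cn1c(Cc2nn(C)c(=O)c3ccccc23)nnc1SCCCCCCCCCCC(=O)Nc1ccccc1Cl` differs from compound 3 in a single place: hydrogen in place of chloro on an aromatic carbon. Within the data shown here, no pair of measured compounds isolates this change, so the expectation rests on the three numbers alone. A small step is expected, probably none beyond the scatter, with a slight drift toward a weaker inhibitor judged more likely than toward a stronger one. Compound 4 is therefore expected to give about 4500 nM, with a range from 1600 nM to 13000 nM. That estimate means an expected step of a 1.4-fold higher number from compound 3 to compound 4 (0.13 log units; within the scatter).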

Compound 4, half-maximal inhibitory concentration: 15000 nM
Estimate against measurement, compound 4: 3.3-fold (0.52 log units) below, and the stated range ends below it.
By their numbers in this assay, from the lowest: compounds 1 and 3 (each within the scatter of the next); then compounds 2 and 4 (each within the scatter of the next).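

In this assay the change from 2,4-dichlorophenyl to 2-chlorophenyl on the long chain gives a clear loss (a 4.5-fold higher number from compound 3 to compound 4 (0.66 log units; beyond the scatter)). The chloro group para to a large group therefore counts toward inhibition in this compound, and hydrogen does not replace it without cost. No measurement available here explains why this position matters.

From the compounds shown here alone, whether a fluoro, methyl or methoxy group at this place would hold the inhibition remains open. So does the outcome of removing the other chloro group instead, or of making the same change on a shorter chain.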